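Tetrabromo benzotriazole series: hydroxyalkyl chain variation

The source may report more compounds than this note shows. Statements on the series, on what has been measured and on what is new or still open speak of the compounds shown alone.

Measured so far:
compound 1 `OCC(O)Cn1nc2c(Br)c(Br)c(Br)c(Br)c2n1`, 56%
compound 2 `OC(CCn1nc2c(Br)c(Br)c(Br)c(Br)c2n1)c1cccc(Cl)c1`, 68%
compound 3 `COc1cccc(C(O)CCn2nc3c(Br)c(Br)c(Br)c(Br)c3n2)c1`, 50%

In a functional assay on CCRF-CEM cells (Homo sapiens) for antiproliferative activity, read by MTT assay, with a stated time of 48 h, tested at 25 uM (on this read-out lower numbers stand for a stronger effect and higher numbers for a weaker effect at the one concentration tested), compound 1 gives 56%, the second highest of the three numbers. Compound 3 gives 50%, which lies within the scatter of compound 1. Compound 2 gives 68%, which stands beyond the scatter from compound 1. Among the measured compounds shown here, the only single-site step in this assay is a number 18 percentage points lower from compound 2 to compound 3 (beyond the scatter).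

Compound 4 `C[C@H](O)CCn1nc2c(Br)c(Br)c(Br)c(Br)c2n1` differs from compound 1 as follows: 2-hydroxypropyl in place of 1,2-dihydroxyethyl on a saturated chain carbon bound to an aromatic nitrogen. For the measured compounds named here, no measured step touches this chain; the one step seen concerns the aromatic substituent of compounds 2 and 3 and does not bear on it. The expected step is therefore no change at the digits printed from compound 1 to compound 4 (within the scatter), none beyond the scatter. Compound 4 is estimated at 56%, between 42% and 70%.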

Compound 4, a percentage reported as activity, at one concentration (the size of the read-out at that concentration, not a potency): 89%
Beside the measured number, compound 4's estimate is 33 percentage points below it, and the stated range ends below it.
By their numbers in this assay, from the lowest: compounds 3 and 1 (each within the scatter of the next); then compound 2; then compound 4.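

In this assay the chain substituent proves sensitive, with 2-hydroxypropyl in place of 1,2-dihydroxyethyl on a saturated chain carbon bound to an aromatic nitrogen giving a number 33 percentage points higher from compound 1 to compound 4 (beyond the scatter) and so a weaker effect. The earlier step concerned only the aromatic substituent, whereas this one shows that the read-out moves with a change on the chain, even though both groups hold 4 heavy atoms and the entering group has 1 hydrogen-bond donor against 2. Nothing available explains this step.

On these data alone, it remains open how an amine, a carboxylic acid or a longer chain would read at this place. As far as these compounds go, the effect of the opposite configuration at the defined stereocentre of compound 4 also remains open.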